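The compounds below may be only part of what the source reports. "The series", "measured", "known", "first", "only" and "open" are said of these compounds alone.

Going by the values given here, in a functional assay on HL-60 cells (Homo sapiens) for antiproliferative activity, read by sulforhodamine B assay, with a stated time of 72 h (a higher number here means a weaker inhibitor, a lower number a stronger inhibitor), compound 1 (`COc1ccccc1NC(=S)N/N=C/c1ccc2ccccc2n1`) gives 91700 nM, the only actual number available. For compound 2 (`NC(=S)N/N=C/c1ccc2cccnc2n1`), the reading of > 100000 nM is a limit of the assay. Compound 3 (`S=C(N/N=C/c1ccc2ccccc2n1)Nc1cccc(Br)c1`) differs from compound 1 by one change: 3-bromophenyl in place of 2-methoxyphenyl on an amide-type nitrogen. Among the compounds with values here, no measured step speaks to this swap on the amide-type nitrogen, so the expectation is loose. Compound 1 at 91700 nM leaves little room for weakening in this assay, so a moderate shift toward stronger inhibition is expected. The expected change is a 2.6-fold lower number from compound 1 to compound 3 (0.42 log units; beyond the scatter). For compound 3 the estimated value is 35000 nM, within an expected range of 6000 nM to 100000 nM.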

Compound 3, half-maximal inhibitory concentration: 53800 nM
For compound 3 the middle estimate is 1.5-fold (0.19 log units) below the measured one; low and high end bracket the measured number.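

In this assay, this amide-type nitrogen now has its first readable step: a 1.7-fold lower number from compound 1 to compound 3 (0.23 log units; within the scatter). Swapping 2-methoxyphenyl for 3-bromophenyl therefore does not separate the two compounds, and both remain weak inhibitors with little room left before the assay's limit: the limit of > 100000 nM in this assay, at which 1 of the 3 values shown sits.

On these data alone, whether an unsubstituted phenyl would read differently from either substituted ring remains open. So does the effect of a non-aromatic group on this nitrogen, such as a short alkyl chain or a morpholine.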